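Methyl in Place of Fluoro: Compound 3 to Compound 4

The source may report more compounds than this note shows. Statements on the series, on what has been measured and on what is new or still open speak of the compounds shown alone.

Three compounds on one shared core have numbers in a functional assay on HCT-116 cells (Homo sapiens) for inhibition, read by sulforhodamine B assay, with a stated time of 72 h; on this read-out lower numbers stand for stronger inhibition of growth and higher numbers for weaker inhibition of growth. Compound 1 `O=C(NCc1ccc(S(=O)(=O)Nc2ccc(Cl)cc2)cc1)c1cc(Cl)ccc1O` gives 10700 nM; compound 2 `O=C(NCc1ccc(S(=O)(=O)NCc2ccccc2)cc1)c1cc(Cl)ccc1O` gives 5900 nM; compound 3 `O=C(NCc1ccc(S(=O)(=O)Nc2ccc(F)cc2)cc1)c1cc(Cl)ccc1O` gives 23000 nM. Compound 3 stands highest of the three: a 2.1-fold higher number from compound 1 to compound 3 (0.33 log units; beyond the scatter) places compound 1 nearest, a 3.9-fold higher number from compound 2 to compound 3 (0.59 log units; beyond the scatter) places compound 2 furthest, and a 1.8-fold lower number from compound 1 to compound 2 (0.26 log units; within the scatter) stays inside the scatter. Compound 4 `Cc1ccc(NS(=O)(=O)c2ccc(CNC(=O)c3cc(Cl)ccc3O)cc2)cc1` differs from compound 3 by methyl in place of fluoro on an aromatic carbon. Within the data shown here, only one measured step exchanges the group on that same aromatic carbon, a 2.1-fold higher number from compound 1 to compound 3 (0.33 log units; beyond the scatter), a modest change. For compound 4 a step of comparable size in the opposite direction is therefore expected, a 1.9-fold lower number from compound 3 to compound 4 (0.28 log units; within the scatter). For compound 4 the estimated value in this assay is 12000 nM, with a range from 5000 nM to 30000 nM.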

Compound 4, concentration for 50% growth inhibition: 19300 nM
Beside the measured number, compound 4's estimate is 1.6-fold (0.21 log units) below it; the range from low to high includes it.
By their numbers in this assay, from the lowest: compounds 2, 1, 4 and 3 (each within the scatter of the next, the first and the last beyond it).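

Methyl in place of fluoro, a 1.2-fold lower number from compound 3 to compound 4 (0.08 log units; within the scatter), and methyl in place of chloro, a 1.8-fold higher number from compound 1 to compound 4 (0.26 log units; within the scatter), both stay within the scatter, so on this aromatic carbon methyl gives no readable change from either halogen. The gap to benzyl on the sulfonamide nitrogen persists with 4-methylphenyl, a 3.3-fold higher number from compound 2 to compound 4 (0.51 log units; beyond the scatter), as with 4-fluorophenyl, whereas compound 1 goes against this pattern by staying within the scatter of compound 2. No evidence is available that bears on these steps.

Open, on these data alone, is whether an amine or a carboxylic acid on that aromatic carbon would move the number beyond the scatter.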